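Cytotoxicity notes: compound 2 to compound 3

The compounds below may be only part of what the source reports. "The series", "measured", "known", "first", "only" and "open" are said of these compounds alone.

Measured so far:
- compound 1 `C/C1=C/C2=C(CC(C)(C)[C@H]2O)[C@H](C)CC[C@@H]1O`; in a functional assay on HepG2 cells (Homo sapiens) for cytotoxicity, read by MTT assay (on this read-out lower numbers stand for stronger inhibition and higher numbers for weaker inhibition), compound 1 gives > 10 ug/mL, a limit of the assay and not a number.
- compound 2 `CC(=O)CC/C=C(/C)CC1=CC(C)(C)CC1=O`; in this assay compound 2 gives > 10 ug/mL, again a limit of the assay.

Within the data shown here, compound 2 therefore stands at the limit, and the same holds for the only other value shown, as set out in the limit of > 10 ug/mL in this assay, at which 2 of the 2 values shown sit. Among the measured compounds shown here, no pair of measured compounds differs in one place, so no measured step is available to lean on.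

Compound 3 `C/C(=C/CC[C@H](C)O)CC1=CC(C)(C)CC1=O` is the next to be measured. Compared with compound 2 the change is 1-hydroxyethyl in place of acetyl on a saturated chain carbon, two bonds along the chain from a double-bonded chain carbon.

The chain is otherwise kept, and the core of compound 2 is unchanged. With both known values sitting at the limit, the step from compound 2 to compound 3 in this assay is expected to be none beyond the scatter, a step that the limit leaves unreadable from compound 2 to compound 3. Compound 3 is expected to give about 20 ug/mL in this assay. The estimate for compound 3 is expected to lie between 10 ug/mL and 60 ug/mL, with the assay most likely again reporting only a limit.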

Compound 3, half-maximal inhibitory concentration: > 10 ug/mL
Compound 3: no number, only a limit; the forecaster's own chance of this, stated with the estimate: 85%; the middle value lies beyond the limit too.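

In this assay compound 2 and compound 3 both give only a limit of the assay, so no step can be read for 1-hydroxyethyl in place of acetyl: the limit of > 10 ug/mL in this assay, at which 3 of the 3 values shown sit.

The compounds shown leave open whether any change to this chain gives a readable number in this assay and how far each compound lies past the limit.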